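Chloro for fluoro on the hydroxy-bearing ring

A few compounds are considered here, and "the series" means these few. Any claim that something is new, unique, unknown or untested is made for them only; others in the source may bear on it.

Compound 1 `O=S(=O)(c1ccc(O)c2ncccc12)C1CCCC1` gives 26 mL/min/kg
Compound 2 `O=S(=O)(c1cc(F)c(O)c2ncccc12)C1CCCC1` gives 0.62 mL/min/kg
Compound 3 `O=S(=O)(c1cc(Cl)c(O)c2ncccc12)C1CCCC1` is not yet measured

In an ADME assay on the whole organism (plasma) for pharmacokinetics, with Rattus norvegicus as the target (a higher number here means faster removal of the compound, a lower number slower removal), compound 2 at 0.62 mL/min/kg stands lowest of the two measured compounds. Compound 3 carries one change from it: chloro in place of fluoro on an aromatic carbon on an aromatic carbon, ortho to a hydroxy group. Among the measured compounds shown here, the only measured step at that carbon, a 42-fold lower number from compound 1 to compound 2 (1.62 log units; beyond the scatter) with fluoro in place of hydrogen, was large. For the measured compounds named here, no measured step exchanges one halogen for another, and a halogen stays on that carbon here. Only a small rise is therefore expected, a 1.5-fold higher number from compound 2 to compound 3 (0.16 log units; within the scatter) and so none beyond the scatter. The estimate for compound 3 is 0.9 mL/min/kg with 0.3 mL/min/kg to 5 mL/min/kg as its range.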

Compound 3, clearance: 0.3 mL/min/kg
For compound 3 the middle estimate is 3.0-fold (0.48 log units) above the measured one; low and high end bracket the measured number.
By their numbers in this assay, from the lowest: compound 3; then compound 2; then compound 1.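

In this assay the exchange of one halogen for another is itself a real change at this carbon: a 2.1-fold lower number from compound 2 to compound 3 (0.32 log units; beyond the scatter), so fluoro and chloro, ortho to a hydroxy group, are not interchangeable here. Measured against hydrogen at the same carbon, chloro also gives a large drop, an 87-fold lower number from compound 1 to compound 3 (1.94 log units; beyond the scatter), so the fall is no longer seen with fluoro alone but with two halogens. Nothing measured here explains either step.

Going by these compounds, whether bromo would extend the order hydrogen, fluoro, chloro remains open. So does whether a non-halogen such as methyl or an amine at this carbon would also lower the number.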